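The source may hold more compounds than are shown below. What is called first, only, known or untested is meant among the compounds shown, and "the series" means these compounds.

Working notes on the shared core, tested in a functional assay on WiDr cells (Homo sapiens) for inhibition; on this read-out lower numbers stand for stronger inhibition and higher numbers for weaker inhibition.

Compound 1 `N#CC1CN1C(=O)Nc1ccc(Cl)cc1Cl` carries a chlorinated phenyl group on the urea nitrogen; in this assay compound 1 gives 2200 nM. Compound 2 `CCCCNC(=O)N1CC1C#N` carries a butyl group on that nitrogen instead; in this assay compound 2 gives 14000 nM. Among the two numbers measured so far, compound 2 stands at the highest; its nearest neighbour is compound 1, whose lower number lies beyond the usual scatter from it.

Compound 3 `CC(C)(C)NC(=O)N1CC1C#N` is the next compound in the set. It differs from compound 2 in one place: tert-butyl in place of butyl on an amide-type nitrogen. Among the measured compounds shown here, no measured pair shows a change of this kind, so the step cannot be read off from the measured compounds. The expectation is that the step from the butyl to the tert-butyl compound is small, none beyond the scatter or at most a slight rise in the number, since nothing in the measured data points to a large move in either direction; the expected step is a 1.1-fold higher number from compound 2 to compound 3 (0.06 log units; within the scatter). In this assay compound 3 is estimated at 16000 nM. For compound 3 the expected range runs from 5000 nM to 50000 nM.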

Compound 3, half-maximal inhibitory concentration: 180000 nM
Beside the measured number, compound 3's estimate is 11-fold (1.05 log units) below it, and the stated range ends below it.
By their numbers in this assay, from the lowest: compound 1; then compound 2; then compound 3.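

In this assay, replacing butyl with tert-butyl on the amide-type nitrogen gives a 13-fold higher number from compound 2 to compound 3 (1.11 log units; beyond the scatter), a large step even though the two compounds have the same atoms, joined differently. Among the compounds shown here, the earlier pair of compound 1 and compound 2 showed only that a chlorinated phenyl group and a butyl group give different numbers at this position; this step shows that the arrangement of the carbons in the group alone can move the number well beyond the scatter, so the atom make-up of the group does not settle the outcome here. No measurement at hand accounts for the size of this step.

The compounds shown leave open whether the rise in the number belongs to tert-butyl alone or would also appear with a less heavily branched group such as isopropyl. They also leave open how a longer straight chain, such as hexyl, or a cyclohexyl ring on the same nitrogen would stand against butyl and the chlorinated phenyl group.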